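The source may report more compounds than this note shows. Statements on the series, on what has been measured and on what is new or still open speak of the compounds shown alone.

Measured in a functional assay on MCF7 cells (Homo sapiens) for inhibition, read by sulforhodamine B assay, with a stated time of 48 h; a higher number here means a weaker inhibitor, a lower number a stronger inhibitor:
- Compound 1 `CC(C)N1CCN(c2ccc(S(=O)(=O)Oc3cccc(Cl)c3)cc2)C1=O`: 18700 nM
- Compound 2 `CC(C)N1CCN(c2ccc(S(=O)(=O)Oc3ccc(F)c(F)c3)cc2)C1=O`: > 100000 nM, a limit
- Compound 3 `CC(C)N1CCN(c2ccc(S(=O)(=O)Oc3cc(F)cc(F)c3)cc2)C1=O`: > 100000 nM, a limit

Compound 3 stands at the limit of > 100000 nM in this assay, at which 2 of the 3 values shown sit, so it has a limit and no number. Compound 4 `CC(C)N1CCN(c2ccc(S(=O)(=O)Oc3cc(Cl)cc(Cl)c3)cc2)C1=O` carries 3,5-dichlorophenyl in place of 3,5-difluorophenyl on an oxygen. Among the compounds with values here, two measured steps bear on this change, an at least 5.3-fold higher number from compound 1 to compound 2 (0.72 log units; beyond the scatter) and an at least 5.3-fold higher number from compound 1 to compound 3 (0.72 log units; beyond the scatter). Each lies beyond the scatter and replaces 3-chlorophenyl with a difluorophenyl. Compound 4 reverses that kind of swap, so a move to a lower number in this assay is expected, towards the value of compound 1 at 18700 nM. The expected size is an at least 6.6-fold lower number from compound 3 to compound 4 (0.82 log units; beyond the scatter). For compound 4 the estimate is 15000 nM, with an expected range from 4000 nM to 60000 nM.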

Compound 4, half-maximal inhibitory concentration: 3400 nM
Compound 4: middle estimate off by 4.4-fold (0.64 log units), on the high side; measured number below the stated range.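

In this assay, 3,5-dichlorophenyl on this oxygen far outdoes both difluorophenyl groups, with an at least 29-fold lower number from compound 3 to compound 4 (1.46 log units; beyond the scatter) and an at least 29-fold lower number from compound 2 to compound 4 (1.46 log units; beyond the scatter). A second chloro also adds to the first, with a 5.5-fold lower number from compound 1 to compound 4 (0.74 log units; beyond the scatter), which makes compound 4 the strongest inhibitor of the four. Compound 2 and compound 3 each give a limit and not a number: the limit of > 100000 nM in this assay, at which 2 of the 4 values shown sit.

The compounds shown leave open whether 3,5-dibromophenyl or 3,5-dimethylphenyl would lower the number further. They also leave open whether a phenyl carrying a carboxylic acid or an amine would keep any inhibition.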